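Sulfonyl substituent step in the oral bioavailability series

A few compounds are considered here, and "the series" means these few. Any claim that something is new, unique, unknown or untested is made for them only; others in the source may bear on it.

Values from an in vivo ADME assay on the whole organism (strain BALB/c) for pharmacokinetics, with Mus musculus as the target, read by LC-MS, at a dose of 5 mg/kg by the oral route (a lower number here means that a smaller share of the oral dose reaches the circulation, a higher number that a larger share of the oral dose reaches the circulation), stand below.

- compound 1 `CCCS(=O)(=O)c1ccc(C)c(C#Cc2cc(C#N)ccc2OCC(=O)O)c1` with 24%
- compound 2 `CN(C)S(=O)(=O)c1ccc(F)c(C#Cc2cc(Cl)ccc2OCC(=O)O)c1` with 58%
- compound 3 `Cc1ccc(S(=O)(=O)N2CCOCC2)cc1C#Cc1cc(Cl)ccc1OCC(=O)O` with 48%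

Compound 3 stands in the upper part of these three numbers: its value (48%) lies within the scatter of compound 2 (58%). The gap between compound 3 and compound 1 lies beyond the scatter, with compound 3 the higher of the two.

Compound 4 `Cc1ccc(S(C)(=O)=O)cc1C#Cc1cc(Cl)ccc1OCC(=O)O` differs from compound 3 in one place, with methyl in place of morpholin-4-yl on a sulfonyl sulfur and the rest of the structure shared. Among the measured compounds shown here, no measured pair shows this change alone, so the data give no direct measure of its size. In this assay a small downward step is expected, and none beyond the scatter. The estimated step of a number 4 percentage points lower from compound 3 to compound 4 (within the scatter) is expected to stay within the scatter. For the measured compounds named here, the range is kept wide because no measured step supports it. For compound 4 the estimated value is 44% with an expected range from 26% to 62% in this measurement.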

Compound 4, oral bioavailability: 49%
Compound 4: the middle estimate sits 5 percentage points below what was measured; low and high end bracket the measured number.
By their numbers in this assay, from the lowest: compound 1; then compounds 3, 4 and 2 (each within the scatter of the next).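

In this assay, among the compounds shown here, the sulfonyl sulfur gives the first readable single-place step: methyl in place of morpholin-4-yl reads as a number 1 percentage points higher from compound 3 to compound 4 (within the scatter). On this one pair, the whole six-membered ring, with its 6 heavy atoms and 1 hydrogen-bond acceptor, can give way to a single methyl carbon on the sulfonyl sulfur without a change in oral bioavailability beyond the scatter. Nothing measured here bears on the reason for this result.

Compounds 1 and 2 differ from compounds 3 and 4 in more than one place, so their steps cannot be read, and the effect of the sulfonyl substituent rests on this single pair. Going by these compounds, whether it holds for other groups on the sulfonyl sulfur, such as cyclopropyl or an unsubstituted amino group, stays open.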